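Urea in place of acylguanidine on a shared sulfone core

The compounds below may be only part of what the source reports. "The series", "measured", "known", "first", "only" and "open" are said of these compounds alone.

Three compounds share one core and differ only in the group carried on a saturated chain carbon bound to a saturated ring carbon. In an assay on isolated protein for displacement of a labelled ligand from 5-hydroxytryptamine receptor 6 (Homo sapiens) (a higher number here means a weaker inhibitor, a lower number a stronger inhibitor), compound 1 `CN(C)S(=O)(=O)NC[C@@H]1CCCc2cc(S(=O)(=O)c3cccc(F)c3)ccc21` gives 2 nM, compound 2 `O=S(=O)(c1cccc(F)c1)c1ccc2c(c1)CCC[C@H]2CN1CCCS1(=O)=O` gives 31.6 nM and compound 3 `N=C(N)NC(=O)C[C@@H]1CCCc2cc(S(=O)(=O)c3cccc(F)c3)ccc21` gives 0.631 nM. Compound 3 thus stands lowest of the three numbers, since the step of a 3.2-fold lower number from compound 1 to compound 3 (0.50 log units; beyond the scatter) and the step of a 50-fold lower number from compound 2 to compound 3 (1.70 log units; beyond the scatter) both lie beyond the scatter. The ring-bearing group fares worst, as the step of a 16-fold higher number from compound 1 to compound 2 (1.20 log units; beyond the scatter) shows.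

Compound 4 `NC(=O)NC[C@@H]1CCCc2cc(S(=O)(=O)c3cccc(F)c3)ccc21` carries a group of 4 heavy atoms (1 carbon, 2 nitrogen, 1 oxygen; no ring) in place of a group of 6 heavy atoms (2 carbon, 3 nitrogen, 1 oxygen; no ring), on a saturated chain carbon bound to a saturated ring carbon. For the measured compounds named here, the measured step that bears most on this change is the one between two open-chain groups, a 3.2-fold lower number from compound 1 to compound 3 (0.50 log units; beyond the scatter), which was modest. The large loss seen in a 50-fold lower number from compound 2 to compound 3 (1.70 log units; beyond the scatter) went with a five-membered ring, and compound 4 has no ring in the entering group. The ureido group, with its hydrogen-bond donors and acceptor on an open chain, sits closer to the group of compound 1 than to that of compound 2. The expected outcome in this assay is therefore a modest rise, a 4.0-fold higher number from compound 3 to compound 4 (0.60 log units; beyond the scatter), rather than a large one. On that basis compound 4 is estimated at 2.5 nM, with a range from 0.6 nM to 10 nM.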

Compound 4, inhibition constant: 0.2 nM
The estimate for compound 4 lay 13-fold (1.10 log units) above the measured number; the measured number lies below the stated range.
By their numbers in this assay, from the lowest: compound 4; then compound 3; then compound 1; then compound 2.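

In this assay, the ureido group shows that this place, on a saturated chain carbon bound to a saturated ring carbon, does not need the larger open-chain group of compound 3: the shorter group still gives a 3.2-fold lower number from compound 3 to compound 4 (0.50 log units; beyond the scatter). The same group also improves on the dimethylsulfamoyl group, with a 10-fold lower number from compound 1 to compound 4 (1.00 log units; beyond the scatter), and the contrast with the ring-bearing group widens to a 160-fold lower number from compound 2 to compound 4 (2.20 log units; beyond the scatter), so that compound 4, whose steps to all three others lie beyond the scatter, is the strongest inhibitor of the four and carries the group with the fewest heavy atoms. Size alone does not order the series, however, since compound 3 has fewer heavy atoms in its group than compound 1 and compound 2, yet nothing available here accounts for any of these steps.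

The compounds shown leave open whether a plain acetamide, a methylurea or a primary amine at this place would hold the number reached by compound 4. They also leave open whether the ureido group would keep its standing on a longer chain, or with the fluorine on the shared core replaced by hydrogen.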